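Swapping the aryl group on the urea nitrogen

The source may report more compounds than this note shows. Statements on the series, on what has been measured and on what is new or still open speak of the compounds shown alone.

Compound 3 `Cc1ccccc1NC(=O)Nc1ccc2c(c1)COC2=O` gives the lowest of the two numbers in a functional assay on cells (T-cell, Mus musculus) for inhibition (on this read-out lower numbers stand for stronger inhibition and higher numbers for weaker inhibition), at 900 nM. Compound 1 `O=C(/C=C/c1ccccn1)Nc1ccc2c(c1)COC2=O` gives 17900 nM in this assay. Compound 2 `O=C(/C=C/c1ccccc1Br)Nc1ccc2c(c1)COC2=O` reaches only a limit in this assay, > 100000 nM, which is not a number. Among the measured compounds shown here, the only measured step, an at least 5.5-fold higher number from compound 1 to compound 2 (0.74 log units; beyond the scatter), is bounded by the limit of > 100000 nM in this assay, at which 1 of the 3 values shown sits, and concerns a ring on a double-bonded chain carbon, not a group on an amide-type nitrogen, so it bears on the present change only loosely. Compound 4 `O=C(Nc1ccc(F)cc1)Nc1ccc2c(c1)COC2=O` differs from compound 3 by 4-fluorophenyl in place of 2-methylphenyl on an amide-type nitrogen. For the measured compounds named here, both groups are six-membered aromatic rings of carbon only with no donors or acceptors and no net charge, and no measured step speaks to such a swap on an amide-type nitrogen. Compound 4 is therefore expected to give about 1500 nM in this assay, with a range from 400 nM to 6000 nM. The step of a 1.7-fold higher number from compound 3 to compound 4 (0.22 log units; within the scatter) is expected to be small, close to the scatter, with a slightly higher number as the more likely direction.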

Compound 4, half-maximal inhibitory concentration: 4190 nM
For compound 4 the middle estimate is 2.8-fold (0.45 log units) below the measured one; measured number inside the range.
By their numbers in this assay, from the lowest: compound 3; then compound 4; then compound 1. At a limit, above all of these: compound 2.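

The swap to 4-fluorophenyl in place of 2-methylphenyl on an amide-type nitrogen gives a 4.7-fold higher number from compound 3 to compound 4 (0.67 log units; beyond the scatter) in this assay, the only step shown at this place. The group on this nitrogen therefore bears on the read-out, even though the group that leaves and the group that enters match in their counts of heavy atoms, hydrogen-bond donors and hydrogen-bond acceptors, and neither carries a net charge. Nothing in the data given explains this step.

On these data alone, compound 3 and compound 4 differ both in the substituent and in where it stands on the ring, so it remains open which of the two carries the step. Also open, as far as these compounds go, is how a plain phenyl, a cyclohexyl ring or a chain ending in an amine on this nitrogen would read in this assay.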